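A few compounds are considered here, and "the series" means these few. Any claim that something is new, unique, unknown or untested is made for them only; others in the source may bear on it.

Measured so far in a physicochemical assay for solubility, in phosphate buffer, at pH 7.4; a higher number here means a more soluble compound, a lower number a less soluble compound:
- compound 1 `CC(=O)N[C@@H]1CCC[C@H](C(=O)Nc2cc(-c3cnc4ccccn34)c(Cl)cn2)C1`: 120000 nM
- compound 2 `CC(=O)N[C@@H]1CCC[C@H](C(=O)Nc2cc(-c3cnc4n3CCC4)c(Cl)cn2)C1`: 490000 nM

Of these two compounds, compound 2 has the higher number, at 490000 nM. The next compound, compound 3 `CC(=O)N[C@@H]1CCC[C@H](C(=O)Nc2cc(-c3cnn4c3NCCC4)c(Cl)cn2)C1`, has not yet been measured and differs from compound 2 in one place: a group of 9 heavy atoms (6 carbon, 3 nitrogen; one five-membered aromatic ring with 2 hetero atoms, one six-membered non-aromatic ring with 2 hetero atoms) in place of a group of 8 heavy atoms (6 carbon, 2 nitrogen; one five-membered non-aromatic ring with 1 hetero atom, one five-membered aromatic ring with 2 hetero atoms), on an aromatic carbon. The five-membered aromatic ring with 2 hetero atoms remains, while the five-membered non-aromatic ring with 1 hetero atom gives way to a six-membered non-aromatic ring with 2 hetero atoms.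

For the measured compounds named here, only one measured step bears on this change: a 4.1-fold higher number from compound 1 to compound 2 (0.61 log units; beyond the scatter). It also swapped one two-ring group for another on the same aromatic carbon, and it was modest. This single step gives a rough size for such a swap but no reliable direction, since its groups differ from the new one. No step beyond the scatter is therefore expected in this assay, although a modest move either way remains possible. The expected change is a 1.4-fold lower number from compound 2 to compound 3 (0.15 log units; within the scatter). For compound 3 the estimated value is 350000 nM, with an expected range of 120000 nM to 800000 nM.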

Compound 3, solubility: 860000 nM
Compound 3: the middle estimate sits 2.5-fold (0.39 log units) below what was measured; measured number above the stated range.
By their numbers in this assay, from the lowest: compound 1; then compounds 2 and 3 (each within the scatter of the next).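

In this assay, this place, on an aromatic carbon ortho to the chloro group, accepts a further two-ring group without a change that can be told from the scatter: a 1.8-fold higher number from compound 2 to compound 3 (0.24 log units; within the scatter). The incoming six-membered non-aromatic ring with 2 hetero atoms adds 1 hydrogen-bond donor to the group, yet compound 2 and compound 3 cannot be separated on these numbers. The wider comparison, a 7.2-fold higher number from compound 1 to compound 3 (0.86 log units; beyond the scatter), means that both groups with a non-aromatic ring now stand beyond the scatter from the six-membered aromatic ring with 1 hetero atom of compound 1, and no compound shown goes against this, though three compounds make a narrow base and nothing measured here explains the result.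

The compounds shown leave open whether the hydrogen-bond donor matters at all, a question that a methyl group on that ring nitrogen could test directly. They also leave open whether two fused rings are needed at this place, or whether a single morpholine or a simple amine would give numbers in the same range.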